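Dropping the Acetyl Group from Compound 2

The source may report more compounds than this note shows. Statements on the series, on what has been measured and on what is new or still open speak of the compounds shown alone.

Compound 1 `CCCCCCCCCCCCCCC[C@@H](C[C@@H](O)C[C@@H](O)C[C@@H](O)C[C@@H](O)C[C@H]1CC=CC(=O)O1)OC(C)=O` gives 5800 nM
Compound 2 `CCCCCCCCCCCCCCC[C@H](C[C@H](O)C[C@H](O)C[C@H](O)C[C@H](O)C[C@@H]1CC=CC(=O)O1)OC(C)=O` gives 9000 nM

In a functional assay on MCF7 cells (Homo sapiens) for cytotoxicity, read by MTT assay, with a stated time of 72 h (on this read-out lower numbers stand for stronger inhibition and higher numbers for weaker inhibition), compound 2 stands level with its mirror image, compound 1 (a 1.6-fold higher number from compound 1 to compound 2 (0.19 log units; within the scatter)). Compound 3 `CCCCCCCCCCCCCCC[C@@H](O)C[C@H](O)C[C@H](O)C[C@H](O)C[C@H](O)C[C@@H]1CC=CC(=O)O1` is compound 2 with hydrogen in place of acetyl on an oxygen on a saturated carbon, a change of acetoxy to hydroxy. Among the measured compounds shown here, no measured step touches this group. For the measured compounds named here, the only step available, the one between compound 1 and compound 2, reflects the fact that compounds 1 and 2 differ only in the configuration as drawn and bears on the new change only loosely. Going by the values given here, with no step of known size to guide it, no shift beyond the scatter is expected in this assay, though that expectation is uncertain in either direction. The expected step is a 1.1-fold lower number from compound 2 to compound 3 (0.05 log units; within the scatter) (an estimate only). The estimated value for compound 3 is 8000 nM (expected range 2500 nM to 25000 nM).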

Compound 3, half-maximal inhibitory concentration: 25800 nM
The estimate for compound 3 lay 3.2-fold (0.51 log units) below the measured number; the whole stated range lies below it.
By their numbers in this assay, from the lowest: compounds 1 and 2 (each within the scatter of the next); then compound 3.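

In this assay, the change of acetoxy to hydroxy gives a 2.9-fold higher number from compound 2 to compound 3 (0.46 log units; beyond the scatter), the only step among these compounds that lies beyond the scatter. The acetyl on this oxygen therefore matters here, with the free hydroxy compound inhibiting more weakly, whereas inverting every stereocentre gave a 1.6-fold higher number from compound 1 to compound 2 (0.19 log units; within the scatter), which stays within the scatter. Nothing given here accounts for this loss.

The compounds shown leave open whether removing the acetyl from the mirror-image compound 1 would raise the number in the same way. They also leave open whether the acetyl itself is needed at this place, or whether a benzoyl ester, a methyl ether or an amine would hold the number near that of compound 2 or move it further.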